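The source may hold more compounds than are shown below. What is called first, only, known or untested is meant among the compounds shown, and "the series" means these compounds.

Measured compounds in a functional assay on KB cells (Homo sapiens) for cytotoxicity, read by sulforhodamine B assay; on this read-out lower numbers stand for stronger inhibition and higher numbers for weaker inhibition:
Compound 1 `C=C1[C@@H](OC(C)=O)C[C@@H]2[C@](C)(CO[Si](C)(C)C(C)(C)C)[C@H](OC(C)=O)CC[C@@]2(C)[C@@H]1C[C@@H](Nc1ccccc1F)C1=CCOC1=O` gives 4740 nM.
Compound 2 `C=C1[C@@H](OC(C)=O)C[C@@H]2[C@](C)(COC=O)[C@H](OC(C)=O)CC[C@@]2(C)[C@@H]1C[C@@H](Nc1ccc(Br)cc1)C1=CCOC1=O` gives 24000 nM.
Compound 3 `C=C1[C@@H](OC(C)=O)C[C@@H]2[C@](C)(COC=O)[C@H](OC(C)=O)CC[C@@]2(C)[C@@H]1C[C@@H](Nc1ccccc1C(=O)O)C1=CCOC1=O` gives 42500 nM.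

Compound 3 holds the highest number of the three. Its nearest neighbour on the numbers is compound 2: a 1.8-fold higher number from compound 2 to compound 3 (0.25 log units; within the scatter). Compound 1 stands furthest off, lower by a margin beyond the scatter.

Compound 4 `C=C1[C@@H](OC(C)=O)C[C@@H]2[C@](C)(COC=O)[C@H](OC(C)=O)CC[C@@]2(C)[C@@H]1C[C@@H](Nc1ccc(OC)cc1)C1=CCOC1=O` differs from compound 3 in one place: 4-methoxyphenyl in place of 2-carboxyphenyl on an amine nitrogen. Among the measured compounds shown here, the only measured step at this position is the one in which one aryl group on the amine nitrogen replaced another, a 1.8-fold higher number from compound 2 to compound 3 (0.25 log units; within the scatter), and it stayed within the scatter. For the measured compounds named here, compound 1 differs from compound 3 in two places at once, so its value shows only that a different aryl group together with a different ester on the shared core can go with a lower number; it says nothing about the aryl change alone. Going by the values given here, on the single relevant step there is no ground to expect the move to 4-methoxyphenyl to shift this assay beyond the scatter, and compound 4 is expected to land close to compound 2 and compound 3 rather than to compound 1. Compound 4 is estimated at 28000 nM, within a range of 11000 nM to 70000 nM, which is expected to amount to a 1.5-fold lower number from compound 3 to compound 4 (0.18 log units; within the scatter).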

Compound 4, half-maximal inhibitory concentration: 32700 nM
The estimate for compound 4 lay 1.2-fold (0.07 log units) below the measured number; the range from low to high includes it.
By their numbers in this assay, from the lowest: compound 1; then compounds 2, 4 and 3 (each within the scatter of the next).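

In this assay, the step of a 1.3-fold lower number from compound 3 to compound 4 (0.11 log units; within the scatter) removes 2-carboxyphenyl, with its hydrogen-bond donor, and brings in 4-methoxyphenyl, which has none, yet the number stays within the scatter. The step of a 1.4-fold higher number from compound 2 to compound 4 (0.13 log units; within the scatter), methoxy in place of bromo on an aromatic carbon, also stays within the scatter, so the three aryl groups on the amine nitrogen of the shared core, which differ in substituent and in where it sits, cannot be told apart in this assay. No supporting measurement bears on this result.

Going by these compounds, it remains open whether the number for compound 1, 4740 nM, goes with its 2-fluorophenyl group or with its silyl ether, as the two differences are not separated here. Also open, on these data alone, is whether a benzyl group or a simple alkyl chain on the amine nitrogen would move the number beyond the scatter.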